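Cyclobutyl Ether at the Aryl Oxygen of an Aminoquinoline

The source may report more compounds than this note shows. Statements on the series, on what has been measured and on what is new or still open speak of the compounds shown alone.

Compound 1 `Nc1ccc2cccc(OCC3CCCO3)c2n1`: > 2000 nM
Compound 2 `Nc1ccc2cccc(OCC3CCOC3)c2n1`: 115 nM
Compound 3 `CSCCOc1cccc2ccc(N)nc12`: > 2000 nM

In an assay on cells with melanin-concentrating hormone receptor 1 (Homo sapiens) as the target, read by radioligand binding (on this read-out lower numbers stand for stronger inhibition and higher numbers for weaker inhibition), the value of compound 3 is a limit of the assay, not a number. It shares the limit of > 2000 nM in this assay, at which 2 of the 3 values shown sit, with compound 1, so compound 3 stands among the weaker members, while compound 2 gives a measurable number. Compound 4 `Nc1ccc2cccc(OC3CCC3)c2n1` differs from compound 3 as follows: cyclobutyl in place of 2-(methylsulfanyl)ethyl on an oxygen on an aromatic ring. The measured steps touching this position are an at least 17-fold higher number from compound 2 to compound 3 (1.24 log units; beyond the scatter) and a step that the two limits leave unreadable from compound 1 to compound 3, the latter unreadable between two limits. For the measured compounds named here, no measured step exchanges an open sulfur chain for a carbon ring, so the direction rests on little. A modest improvement is expected, an at least 2.2-fold lower number from compound 3 to compound 4 (0.34 log units; beyond the scatter), with compound 4 estimated at 900 nM, within 150 nM to 3000 nM.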

Compound 4, half-maximal inhibitory concentration: > 2000 nM
Compound 4: no number, only a limit; the forecaster's own chance of this, stated with the estimate: 45%; at least 2.2-fold (0.34 log units) between middle value and limit.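

Compound 4 gives only a limit of the assay, not a number, and so joins the weak group: the limit of > 2000 nM in this assay, at which 3 of the 4 values shown sit. Cyclobutyl in place of (oxolan-3-yl)methyl gives an at least 17-fold higher number from compound 2 to compound 4 (1.24 log units; beyond the scatter), so a small carbon ring with no hydrogen-bond acceptor does not keep the measurable value of compound 2. The steps from compound 1 and compound 3 to compound 4 cannot be read, since both ends are limits.

Compound 1, compound 3 and compound 4 therefore remain unranked. Going by these compounds, whether an amine or a longer chain ending in an oxolane ring would give a measurable number on this oxygen stays open.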